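A few compounds are considered here, and "the series" means these few. Any claim that something is new, unique, unknown or untested is made for them only; others in the source may bear on it.

Among the measured compounds shown here, compound 1 `FC(F)(F)c1ccc(NCc2cn(-c3ccccc3)nc2-c2ccc(Br)cc2)cc1` is the only compound with a numbered result in an ADME assay on BHK-21 cells (Mesocricetus auratus) for cytotoxicity, read by MTT assay, with a stated time of 72 h (a lower number here means that less compound is tolerated, a higher number that more compound is tolerated), where compound 1 gives 20000 nM. Compound 2 `Cc1ccc(NCc2cn(-c3ccccc3)nc2-c2ccc(Br)cc2)cc1` reaches only a limit of the assay, > 100000 nM. For the measured compounds named here, the step of an at least 5.0-fold higher number from compound 1 to compound 2 (0.69 log units; beyond the scatter) is the one measured change, and the limit of > 100000 nM in this assay, at which 1 of the 2 values shown sits, is the single limit among the values. Going by the values given here, that step sits on a different ring from the change to compound 3 `FC(F)(F)c1ccc(NCc2cn(-c3ccccc3)nc2-c2ccc(C(F)(F)F)cc2)cc1`, which is trifluoromethyl in place of bromo on an aromatic carbon, so no measured step bears on it, and no shift beyond the scatter is anticipated in this assay. Compound 3 is therefore expected to give 20000 nM, between 7000 nM and 60000 nM, an expected step of no change at the digits printed from compound 1 to compound 3 (within the scatter).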

Compound 3, half-maximal cytotoxic concentration: 27000 nM
The estimate for compound 3 lay 1.4-fold (0.13 log units) below the measured number; measured number inside the range.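

In this assay, the position carrying bromo now has a measured change of its own: a 1.4-fold higher number from compound 1 to compound 3 (0.13 log units; within the scatter). Trifluoromethyl in place of bromo on this ring therefore leaves the reading within the scatter, whereas the earlier measured step lay on a different ring. Nothing measured here offers a cause for this result. The compounds shown leave open whether an amine or a carboxylic acid in place of bromo would shift the reading, and whether methyl on this ring would act as it did on the other.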